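The compounds below may be only part of what the source reports. "The series", "measured", "known", "first", "only" and "open" are said of these compounds alone.

The measured compounds:

Compound 1, `O=S(=O)(Nc1ccc2oc(-c3ccccc3)nc2c1)c1cccc(C(F)(F)F)c1` — in an assay on cells for inhibition of HSP60/HSP10 (Homo sapiens), with a stated time of 60 min (on this read-out lower numbers stand for stronger inhibition and higher numbers for weaker inhibition), compound 1 gives > 100000 nM, which is a limit of the assay and not a number.
Compound 2, `O=S(=O)(Nc1ccc2oc(-c3ccccc3)nc2c1)c1ccc(Cl)c(C(F)(F)F)c1` — compound 2 gives > 100000 nM, again a limit and not a number.
Compound 3, `O=S(=O)(Nc1ccc(-c2nc3cc(NS(=O)(=O)c4ccccc4F)ccc3o2)cc1)c1ccccc1F` — compound 3 gives 57000 nM.

Compound 1 thus stands at the limit of this assay, as does compound 2, while compound 3 is the only one of the three with a numerical value. Going by the values given here, the single step among the measured compounds, a step that the two limits leave unreadable from compound 1 to compound 2, cannot be read in size because both of its ends sit at the limit of > 100000 nM in this assay, at which 2 of the 3 values shown sit.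

Compound 4, `O=S(=O)(Nc1ccc2oc(-c3ccccc3)nc2c1)c1cccc(O)c1`, differs from compound 1 by hydroxy in place of trifluoromethyl on an aromatic carbon. Among the compounds with values here, no measured step carries this change, and the only step leaving compound 1 is unreadable, so neither a size nor a direction beyond the scatter can be foreseen for the step in this assay. On that basis compound 4 is expected to remain weak, with an estimated step of a number no higher from compound 1 to compound 4 (the limit leaves the size open). Compound 4 is estimated at 100000 nM, in a range from 30000 nM to 300000 nM.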

Compound 4, half-maximal inhibitory concentration: 76000 nM
For compound 4 the middle estimate is 1.3-fold (0.12 log units) above the measured one; low and high end bracket the measured number.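

Hydroxy in place of trifluoromethyl, on an aromatic carbon of a six-membered aromatic ring of carbon only, gives the core of compound 1 a number rather than a limit in this assay: compound 4 gives 76000 nM. The step is an at least 1.3-fold lower number from compound 1 to compound 4 (0.11 log units; that floor lies within the scatter), so this change shows no firm gain, and only a floor can be read. Compound 1 itself stands at a limit and not a number: the limit of > 100000 nM in this assay, at which 2 of the 4 values shown sit.

The compounds shown leave open whether an amine, a methoxy group or a carboxylic acid on the same aromatic carbon would also give a number, and how that number would compare with the one for compound 4. Also open, on these data alone, are the true size of the step and whether hydroxy would give a number on the core of compound 2 as well.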